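The source may hold more compounds than are shown below. What is called first, only, known or untested is meant among the compounds shown, and "the series" means these compounds.

Of the compounds shown here, three have been measured, all built on closely related cores. Compound 1 `C#CCN1CCC(COC(=O)N(C)CC)CC1` carries a propargyl group on an amine nitrogen in a ring. In an assay on BTI-TN-5B1-4 cells for inhibition of Amine oxidase [flavin-containing] A (Homo sapiens), read by fluorescence and Amplex Red, using microsomes, with a stated time of 15 min (a higher number here means a weaker inhibitor, a lower number a stronger inhibitor), compound 1 gives only a limit of the assay, > 100000 nM. Compound 2 `C#CCN1CCCC(COC(=O)N(C)CC)C1` contains the same atoms as compound 1, joined differently; the difference between the two cores is not broken down here. In this assay compound 2 likewise gives only a limit, > 100000 nM. Compound 3 `CCN(C)C(=O)OCC1CCN(Cc2ccccc2)CC1` differs from compound 1 by phenyl in place of ethynyl on a saturated chain carbon bound to an amine nitrogen in a ring. In this assay compound 3 gives only a limit as well, > 100000 nM. The step that the two limits leave unreadable from compound 1 to compound 3 therefore cannot be sized, since (the limit of > 100000 nM in this assay, at which 3 of the 3 values shown sit).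

Compound 4 `CCN(C)C(=O)OCC1CCCN(Cc2ccccc2)C1` has not yet been measured. Within the data shown here, it differs from compound 2 by phenyl in place of ethynyl on a saturated chain carbon bound to an amine nitrogen in a ring, the same change as the one from compound 1 to compound 3. Because (the limit of > 100000 nM in this assay, at which 3 of the 3 values shown sit), the step that the limit leaves unreadable from compound 2 to compound 4 is expected to change little that can be read. Compound 4 is accordingly estimated at 200000 nM, most likely between 50000 nM and 1000000 nM, with a strong chance that only a limit is reported again.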

Compound 4, half-maximal inhibitory concentration: > 100000 nM
Compound 4 was reported as a limit; the forecaster's own chance of this, stated with the estimate: 85%; the middle value lies beyond the limit too.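

In this assay compound 4 gives only a limit, > 100000 nM. The change of propargyl to benzyl between compound 2 and compound 4 therefore cannot be sized: the limit of > 100000 nM in this assay, at which 4 of the 4 values shown sit. The compounds shown leave open how strongly any of them inhibits the enzyme, and whether any change to the shared core would yield a measurable value.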